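Swapping Chloro for Methyl on the Pyridine Carbonyl

The source may hold more compounds than are shown below. What is called first, only, known or untested is meant among the compounds shown, and "the series" means these compounds.

Measured compounds in a functional assay on WM 266-4 cells (Homo sapiens) for antiproliferative activity, read by MTT assay, with a stated time of 24 h; a lower number here means a stronger inhibitor of growth, a higher number a weaker inhibitor of growth:
compound 1 `COc1ccc(C2=NN(C(=O)c3ccc(C)nc3)C(c3ccc(Cl)cc3)C2)cc1` gives 890 nM
compound 2 `COc1ccc(C2=NN(C(=O)c3ccc(C)nc3)C(c3ccc(Br)cc3)C2)cc1` gives 4280 nM
compound 3 `COc1ccc(C2=NN(C(=O)c3ccc(Cl)nc3)C(c3ccc(OCc4ccccc4)cc3)C2)cc1` gives 10600 nM

Among these three, compound 3 gives the highest number, so it is the weakest growth inhibitor of the set: its value lies above that of compound 2 and well above that of compound 1, and both gaps are larger than the usual scatter of repeated measurements.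

Compound 4 `COc1ccc(C2=NN(C(=O)c3ccc(C)nc3)C(c3ccc(OCc4ccccc4)cc3)C2)cc1` is the next compound to be tested. It differs from compound 3 in one place: methyl in place of chloro on an aromatic carbon.

Going by the values given here, only one measured step is available, a 4.8-fold higher number from compound 1 to compound 2 (0.68 log units; beyond the scatter), and it concerns a halogen exchange on the other aryl ring of the shared core, not the pyridine carbonyl. Among the compounds with values here, no measured pair shows what happens when the substituent on the pyridine is changed, so that step gives only a rough sense of how much a single small swap can move this assay. With nothing bearing directly on the change, the expectation for compound 4 is a number close to that of compound 3, with a step that is not expected to exceed the scatter in either direction, written as a 1.2-fold lower number from compound 3 to compound 4 (0.07 log units; within the scatter). Compound 4 is therefore estimated to give 9000 nM in this assay, within a range from 3000 nM to 27000 nM.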

Compound 4, concentration for 50% growth inhibition: 7950 nM
Compound 4: the middle estimate sits 1.1-fold (0.05 log units) above what was measured; the range from low to high includes it.
By their numbers in this assay, from the lowest: compound 1; then compounds 2, 4 and 3 (each within the scatter of the next, the first and the last beyond it).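

In this assay, going by these compounds alone, the exchange of 6-chloropyridin-3-yl for 6-methylpyridin-3-yl gives the first direct reading at this position: with the benzyloxy group kept in place, there is a 1.3-fold lower number from compound 3 to compound 4 (0.12 log units; within the scatter) and this step lies within the scatter, so chloro and methyl cannot be told apart here. Compound 4 also shows how benzyloxy compares with the halogens on the other aryl ring while the methyl stays on the pyridine: there is a 1.9-fold higher number from compound 2 to compound 4 (0.27 log units; within the scatter) and this step is also within the scatter, so benzyloxy and bromo cannot be told apart, whereas an 8.9-fold higher number from compound 1 to compound 4 (0.95 log units; beyond the scatter) and this larger step lies beyond the scatter, which sets the chloro compound apart from its benzyloxy partner. Nothing available here explains why these numbers fall as they do.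

At this position the compounds shown carry only chloro and methyl, so it remains open whether an amine or a carboxylic acid there would change growth inhibition. Within the data shown here, the chloro and methyl pair is also seen only with benzyloxy on the other aryl ring, leaving open whether the same exchange would make so little difference with chloro or bromo on that ring.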